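From phenyl to 3,4-difluorophenyl on the sulfonyl sulfur

A few compounds are considered here, and "the series" means these few. Any claim that something is new, unique, unknown or untested is made for them only; others in the source may bear on it.

- compound 1 `Cc1ccccc1S(=O)(=O)c1ccc(CNC(=O)c2cc3cnccc3[nH]2)cc1` gives 15%
- compound 2 `O=C(NCc1ccc(S(=O)(=O)c2cccc(C(F)(F)F)c2)cc1)c1cc2cnccc2[nH]1` gives 49%
- compound 3 `O=C(NCc1ccc(S(=O)(=O)c2ccccc2)cc1)c1cc2cnccc2[nH]1` gives 54%

These numbers come from an ADME assay on microsomes from liver (Mus musculus) for metabolic stability, read by LC-MS, with a stated time of 30 min, tested at 1 uM; a higher number here means that more of the compound is left, a lower number that less of the compound is left. Compound 3 shares the upper end of this small set with compound 2 (a number 5 percentage points higher from compound 2 to compound 3 (within the scatter)) and stands well clear of compound 1 (a number 39 percentage points higher from compound 1 to compound 3 (beyond the scatter)).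

The next compound, compound 4 `O=C(NCc1ccc(S(=O)(=O)c2ccc(F)c(F)c2)cc1)c1cc2cnccc2[nH]1`, differs from compound 3 in one place (3,4-difluorophenyl in place of phenyl on a sulfonyl sulfur). The change is 3,4-difluorophenyl in place of phenyl on a sulfonyl sulfur.

For the measured compounds named here, two measured steps bear on this, as both change the same ring. Trading trifluoromethyl for hydrogen made no difference beyond the scatter (a number 5 percentage points higher from compound 2 to compound 3 (within the scatter)), whereas trading methyl for hydrogen made a large one (a number 39 percentage points higher from compound 1 to compound 3 (beyond the scatter)). Compound 4 has no methyl on this ring. Like compound 2 (49%), it carries fluorine there, so compound 2 is the closer guide. Going by the values given here, still, no measured compound has this exact ring, and three compounds make a thin basis.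

The expected change in this assay is therefore no step beyond the scatter, in either direction (a number 2 percentage points lower from compound 3 to compound 4 (within the scatter)). For compound 4 the estimate is 52%, with an expected range from 35% to 70%.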

Compound 4, percent of the compound remaining: 58%
Beside the measured number, compound 4's estimate is 6 percentage points below it; the range from low to high includes it.
By their numbers in this assay, from the lowest: compound 1; then compounds 2, 3 and 4 (each within the scatter of the next).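

In this assay, 3,4-difluorophenyl and phenyl on the sulfonyl sulfur give readings that cannot be told apart (a number 4 percentage points higher from compound 3 to compound 4 (within the scatter)), so this position takes two fluorines on the ring with no step beyond the scatter. The same holds when 3,4-difluorophenyl takes the place of 3-(trifluoromethyl)phenyl (a number 9 percentage points higher from compound 2 to compound 4 (within the scatter)), whereas the gap is large when it takes the place of 2-methylphenyl (a number 43 percentage points higher from compound 1 to compound 4 (beyond the scatter)), which leaves compound 1 as the only one of the four that stands apart, now against three different rings. Nothing available explains why these rings read alike or why compound 1 differs.

For the compounds shown here, with a single methyl-bearing ring in the set, it stays open whether any methyl on this ring gives a low reading or only the one in 2-methylphenyl, and 4-methylphenyl or a 2-fluorophenyl would help to separate the two. Rings carrying a methoxy group, an amine or a carboxylic acid are also absent from the compounds shown, as is a pyridine ring on the sulfonyl sulfur, so the reach of this flat stretch beyond fluorine, trifluoromethyl and hydrogen remains unknown.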